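Two-aryl quinazoline series: cyclopentyl replacing 2-nitrophenyl

This account rests on a few compounds, and the source may have more. Where it says the series, first, only, none or still open, it means among the compounds named here.

Measured so far:
compound 1 `FC(F)(F)c1ccccc1-c1nc(NCc2ccc(-c3ccc(Cl)c(Cl)c3)cc2)c2ccccc2n1` — 2200 nM
compound 2 `O=[N+]([O-])c1ccccc1-c1nc(NCc2ccc(-c3cccnc3)cc2)c2ccccc2n1` — 7800 nM

In an assay on a protein complex for inhibition of ubiquitin carboxyl-terminal hydrolase 1/WD repeat-containing protein 48 (Homo sapiens), read by fluorescence (a lower number here means a stronger inhibitor, a higher number a weaker inhibitor), compound 1 gives 2200 nM. Compound 2 in this assay gives 7800 nM, the highest number of the two, and its gap to compound 1 lies beyond the usual scatter, so compound 2 is the weaker inhibitor of the pair. Within the data shown here, the two compounds differ in more than one place, so no single step between them is resolved.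

Compound 3 `c1cncc(-c2ccc(CNc3nc(C4CCCC4)nc4ccccc34)cc2)c1` has not yet been measured. It differs from compound 2 in one place: cyclopentyl in place of 2-nitrophenyl on an aromatic carbon. The change swaps a six-membered aromatic ring carrying two hydrogen-bond acceptors for a saturated five-membered ring with none. Among the measured compounds shown here, no measured step covers this exchange, so the expectation rests only on the standing of compound 2. A step of modest size is expected from compound 2 to compound 3, a 1.5-fold higher number from compound 2 to compound 3 (0.19 log units; within the scatter), in the direction of a weaker inhibitor, though it may fall within the scatter. Compound 3 is expected to give about 12000 nM in this assay, with a range from 3500 nM to 40000 nM.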

Compound 3, half-maximal inhibitory concentration: "not active" (no number reported)
Nothing numeric was reported for compound 3, and the estimate cannot be compared.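

In this assay, among these compounds, compound 3 is reported as not active, with no number, so no step from compound 2 to compound 3 can be read. The compounds shown leave open how far cyclopentyl in place of 2-nitrophenyl moves the number on this core. No measurement shown here bears on this result.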